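Moving the hydroxyl pair: compound 2 to compound 3

The compounds below may be only part of what the source reports. "The series", "measured", "known", "first", "only" and "open" are said of these compounds alone.

In a functional assay on K562 cells (Homo sapiens) for antiproliferative activity, with a stated time of 72 h (on this read-out higher numbers stand for weaker inhibition and lower numbers for stronger inhibition), compound 1 `OC[C@H]1O[C@@H](n2cnc3c(NCc4ccc(F)cc4)ncnc32)[C@H](O)[C@@H]1O` gives 2700 nM and compound 2 `OC[C@H]1O[C@@H](n2cnc3c(NCc4cccc(O)c4O)ncnc32)[C@H](O)[C@@H]1O` gives 25800 nM. Compound 2 therefore holds the higher of the two numbers, and so shows the weaker inhibition of the pair.

Among the compounds with values here, compound 3 `OC[C@H]1O[C@@H](n2cnc3c(NCc4cc(O)cc(O)c4)ncnc32)[C@H](O)[C@@H]1O` keeps the shared core and alters only one group: 3,5-dihydroxyphenyl in place of 2,3-dihydroxyphenyl on a saturated chain carbon bound to a nitrogen on an aromatic ring. The atoms stay the same but are joined differently, with 3,5-dihydroxyphenyl in place of 2,3-dihydroxyphenyl.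

Within the data shown here, one measured step bears on this change: a 9.6-fold higher number from compound 1 to compound 2 (0.98 log units; beyond the scatter). This modest step replaced 4-fluorophenyl with 2,3-dihydroxyphenyl, so it compares different groups. Among the measured compounds shown here, no measured pair shows the effect of rearranging a dihydroxyphenyl group, which leaves the basis for a prediction thin.

Compound 3 keeps a dihydroxyphenyl group, as does compound 2 at 25800 nM, so a value near that one is expected in this assay. No step beyond the scatter is expected, with only a slight lean toward a lower number. The expected step is a 1.6-fold lower number from compound 2 to compound 3 (0.21 log units; within the scatter). The estimate for compound 3 is 16000 nM, with an expected range of 5000 nM to 50000 nM.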

Compound 3, half-maximal inhibitory concentration: > 166000 nM
Compound 3: only a limit was reported; the forecaster's own chance of this, stated with the estimate: 15%; at least 10-fold (1.01 log units) between middle value and limit.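

In this assay compound 3 gives > 166000 nM, which is a limit and not a number: the limit of > 166000 nM in this assay, at which 1 of the 3 values shown sits.

Rearranging the hydroxyl pair alone, with the same atoms and the same counts of hydrogen-bond donors and acceptors, gives an at least 6.4-fold higher number from compound 2 to compound 3 (0.80 log units; beyond the scatter); on a saturated chain carbon bound to a nitrogen on an aromatic ring, the read-out therefore follows the arrangement of the two hydroxyls and not merely the presence of a dihydroxyphenyl group. Measured from the 4-fluorophenyl group, the 3,5-dihydroxyphenyl group gives an at least 61-fold higher number from compound 1 to compound 3 (1.78 log units; beyond the scatter), and with the earlier step of a 9.6-fold higher number from compound 1 to compound 2 (0.98 log units; beyond the scatter) both dihydroxyphenyl groups shown lie on the weaker side of 4-fluorophenyl.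

The limit fixes only a minimum for both new steps, so their true sizes stay open, and nothing shown separates the effect of either hydroxyl from that of the pair. Also open, on these data alone, is how a phenyl group carrying a single hydroxyl, or methoxy groups in place of the hydroxyl pair, would read at this place in this assay.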